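A cyclopropyl for methyl swap, repeated on a second core

This account rests on a few compounds, and the source may have more. Where it says the series, first, only, none or still open, it means among the compounds named here.

Of the compounds shown here, three have been measured in a functional assay on CHO cells for agonist activity at Free fatty acid receptor 1 (Homo sapiens), read by FLIPR and calcium flux; on this read-out higher numbers stand for an effect only at larger amounts of compound and lower numbers for an effect already at smaller amounts. Compound 1 `CCOc1ccc(C)c(-c2cccc(COc3ccc(OCC(=O)O)c(F)c3)c2)c1` gives 220 nM, compound 2 `Cc1ccc(OCC2CC2)cc1-c1cccc(COc2ccc(OCC(=O)O)c(F)c2)c1` gives 340 nM, and compound 3 `CCOc1cccc(-c2cccc(COc3ccc(OCC(=O)O)c(F)c3)c2)c1` gives 480 nM.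

Compound 2 differs from compound 1 by cyclopropyl in place of methyl on a saturated chain carbon bound to an oxygen on an aromatic ring. That change made a 1.5-fold higher number from compound 1 to compound 2 (0.19 log units; within the scatter). Compound 3 differs from compound 1 by hydrogen in place of methyl on an aromatic carbon, and that change made a 2.2-fold higher number from compound 1 to compound 3 (0.34 log units; beyond the scatter).

Compound 4 `O=C(O)COc1ccc(OCc2cccc(-c3cccc(OCC4CC4)c3)c2)cc1F` has not yet been measured. It differs from compound 3 by cyclopropyl in place of methyl on a saturated chain carbon bound to an oxygen on an aromatic ring. This is the same change as the one from compound 1 to compound 2, now made on the core of compound 3 instead of the core of compound 1; the two cores differ by the methyl described above.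

For compound 4 in this assay the expected step is a 1.5-fold higher number from compound 3 to compound 4 (0.16 log units; within the scatter), resting on the step of a 1.5-fold higher number from compound 1 to compound 2 (0.19 log units; within the scatter) seen when the same change was made on compound 1. Since that earlier step lay within the scatter, the estimate for compound 4 is 700 nM, expected to fall between 350 nM and 1400 nM.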

Compound 4, half-maximal effective concentration: 670 nM
For compound 4 the middle estimate is 1.0-fold (0.02 log units) above the measured one, and the stated range covers the measured number.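

The cyclopropyl for methyl swap on the core of compound 3 made a 1.4-fold higher number from compound 3 to compound 4 (0.14 log units; within the scatter), and this step can be set beside the one on the core of compound 1: the same change on two cores in this assay, a 1.5-fold higher number (0.19 log units; within the scatter) from compound 1 to compound 2 and a 1.4-fold higher number (0.14 log units; within the scatter) from compound 3 to compound 4, 1.1-fold (0.04 log units) apart, within the scatter of two such steps. Hydrogen in place of methyl on an aromatic carbon, read on the two compounds carrying cyclopropylmethoxy, made a 2.0-fold higher number from compound 2 to compound 4 (0.29 log units; within the scatter), and this step can be set beside the one read on the two compounds carrying ethoxy: the same change on two cores in this assay, a 2.2-fold higher number (0.34 log units; beyond the scatter) from compound 1 to compound 3 and a 2.0-fold higher number (0.29 log units; within the scatter) from compound 2 to compound 4, 1.1-fold (0.04 log units) apart, within the scatter of two such steps. Across these four compounds, each change therefore had a similar size on both cores, but this covers only two cores, and both cyclopropyl steps lie within the usual scatter, so they do not show that the swap itself shifts the number in this assay.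

The compounds shown leave open whether a longer chain such as propyl, or an amine, in place of the cyclopropyl would carry over in the same way. They also leave open how a chlorine in place of the methyl on the aromatic carbon would behave on either core.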